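The source may report more compounds than this note shows. Statements on the series, on what has been measured and on what is new or still open speak of the compounds shown alone.

In an ADME assay on microsomes from liver (Homo sapiens) for metabolic stability, read by LC-MS, using NADPH, tested at 5 uM (on this read-out lower numbers stand for a shorter-lived compound and higher numbers for a longer-lived compound), three close relatives of a shared core have been measured. Compound 1 `Cc1cc(-c2ccccc2)n(/C(N)=N/S(=O)(=O)c2cc(C)c(Cl)cc2SCc2cccc3ccccc23)n1` gives 0.256 h. Compound 2 `Cc1cc(-c2ccccc2)n(/C(N)=N/S(=O)(=O)c2cc(C)c(Cl)cc2SCc2cccc(C(F)(F)F)c2)n1` gives 0.169 h, and compound 3 `Cc1cc(-c2ccccc2)n(/C(N)=N/S(=O)(=O)c2cc(C)c(Cl)cc2SCc2cccc(Cl)c2)n1` gives 0.205 h. On these numbers compound 3 stands second highest of the three, but its gap to its nearest neighbour, compound 2, and to its furthest, compound 1, both fall within the usual scatter, so the three cannot be told apart in this assay. The steps say the same: a 1.2-fold lower number from compound 1 to compound 3 (0.10 log units; within the scatter), a 1.2-fold higher number from compound 2 to compound 3 (0.08 log units; within the scatter) and a 1.5-fold lower number from compound 1 to compound 2 (0.18 log units; within the scatter).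

Compound 4 `Cc1cc(-c2ccccc2)n(/C(N)=N/S(=O)(=O)c2cc(C)c(Cl)cc2SCc2ccccc2C(F)(F)F)n1` has not yet been measured. It differs from compound 3 in one place: 2-(trifluoromethyl)phenyl in place of 3-chlorophenyl on a saturated chain carbon bound to a sulfur. Two of the measured steps bear on this change, since they also exchange the group on the saturated chain carbon bound to a sulfur: the step from compound 1 to compound 3 and the step from compound 1 to compound 2, both within the scatter. The exchange of chloro for trifluoromethyl on an aromatic carbon, from compound 2 to compound 3, is within the scatter as well. Nothing among these steps moves this assay beyond its scatter, so no step beyond the scatter is expected here either. Compound 4 is estimated at 0.2 h, within 0.12 h to 0.35 h. This estimate means an expected 1.0-fold lower number from compound 3 to compound 4 (0.01 log units; within the scatter).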

Compound 4, half-life: 0.306 h
The estimate for compound 4 lay 1.5-fold (0.18 log units) below the measured number; low and high end bracket the measured number.
By their numbers in this assay, from the lowest: compounds 2, 3, 1 and 4 (each within the scatter of the next).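

The position on a saturated chain carbon bound to a sulfur now carries a fourth group in this assay, and 2-(trifluoromethyl)phenyl stays within the scatter of all three earlier groups, whether it replaces 3-chlorophenyl (a 1.5-fold higher number from compound 3 to compound 4 (0.17 log units; within the scatter)) or naphthalen-1-yl (a 1.2-fold higher number from compound 1 to compound 4 (0.08 log units; within the scatter)). The earlier compounds shown here only exchanged one group for a different one, whereas the new pair keeps trifluoromethyl on the phenyl ring and changes only its ring position, from the 3-(trifluoromethyl)phenyl to the 2-(trifluoromethyl)phenyl group, and even this gives no separation beyond the scatter (a 1.8-fold higher number from compound 2 to compound 4 (0.26 log units; within the scatter)). No measurement among the data shown accounts for any of these numbers.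

From the compounds shown here alone, all four groups at this position are aromatic carbon rings, so it remains open whether a basic amine, a carboxylic acid or a longer saturated chain in the same place would give a step beyond the scatter. Also open, going by these compounds, is whether 2-chlorophenyl would match 3-chlorophenyl here, which would show if the same ring-position change behaves alike with chloro as with trifluoromethyl.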